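Replacing the Propyl Amide Chain of Compound 1 with 2-Fluorobenzyl

The source may report more compounds than this note shows. Statements on the series, on what has been measured and on what is new or still open speak of the compounds shown alone.

Compound 1 `C=CC1=C(C(=O)NCCC)C(c2ccc(F)cc2)OC1` in a functional assay on SW480 cells (Homo sapiens) for cytotoxicity, read by MTT assay, with a stated time of 24 h (a higher number here means a weaker inhibitor, a lower number a stronger inhibitor), gives only a limit, > 100000 nM.
Compound 2 `C=CC1=C(C(=O)O)C(c2ccc(F)cc2)OC1` in this assay gives only a limit, > 100000 nM.
Compound 3 `C=CC1=C(C(=O)NCCC)C(c2ccc(Cl)c(Cl)c2)OC1` in this assay gives only a limit, > 100000 nM.

Compound 1 therefore stands at the limit of this assay, with no numerical value of its own. The change to compound 4 `C=CC1=C(C(=O)NCc2ccccc2F)C(c2ccc(F)cc2)OC1` is 2-fluorophenyl in place of ethyl on a saturated chain carbon bound to an amide-type nitrogen. For the measured compounds named here, the only measured step at the amide, a step that the two limits leave unreadable from compound 1 to compound 2, is unreadable, and the limit of > 100000 nM in this assay, at which 3 of the 3 values shown sit, shows that every value so far sits at the same limit. Nothing measured points to a readable step, so compound 4 is expected to stay at that limit, an estimate of 100000 nM within 30000 nM to 300000 nM, meaning an expected step of a number no higher from compound 1 to compound 4 (the limit leaves the size open).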

Compound 4, half-maximal inhibitory concentration: > 100000 nM
Compound 4 gave a limit, no number (the forecaster's own chance of this, stated with the estimate: 80%); the middle value lies on the limit itself.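

For the compounds shown here, compound 1 and compound 4 each give only a limit, so no step between them can be read. As far as these compounds go, whether any change to the shared core would give a numerical value in this assay remains open.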